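Tellurium to Selenium Exchange on a Cytotoxic Amide Series

A few compounds are considered here, and "the series" means these few. Any claim that something is new, unique, unknown or untested is made for them only; others in the source may bear on it.

Measured so far:
compound 1 `COc1ccc(N(CC(=O)NCCC[Te]c2ccccc2)C(=O)c2ccccc2)cc1` — 27000 nM
compound 2 `O=C(COC(=O)C#Cc1ccccc1)NCCC[Te]c1ccccc1` — 1000 nM

In a functional assay on MCF7 cells (Homo sapiens) for cytotoxicity, read by MTT assay, with a stated time of 24 h (a lower number here means a stronger inhibitor, a higher number a weaker inhibitor), compound 1 stands at the higher of the two numbers, with compound 2 giving the lower one; the gap between them lies beyond the scatter. Compound 3 `COc1ccc(N(CC(=O)NCCC[Se]c2ccccc2)C(=O)c2ccccc2)cc1` differs from compound 1 by a group of 7 heavy atoms (6 carbon, 1 selenium; one six-membered aromatic ring of carbon only) in place of a group of 7 heavy atoms (6 carbon, 1 tellurium; one six-membered aromatic ring of carbon only), on a saturated chain carbon, three bonds along the chain from an amide-type nitrogen. Among the measured compounds shown here, no measured pair shows what this exchange does on its own. The step of a 1.9-fold higher number from compound 1 to compound 3 (0.27 log units; within the scatter) is expected to be modest and toward a higher number, at or just beyond the scatter. Compound 3 is estimated at 50000 nM, with a range of 15000 nM to 150000 nM.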

Compound 3, half-maximal inhibitory concentration: >= 100000 nM
Compound 3 gave a limit, no number; the forecaster's own chance of this, stated with the estimate: 20%; middle value at least 2.0-fold (0.30 log units) from the limit.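

In this assay, the selenium group in place of the tellurium group, on a saturated chain carbon, three bonds along the chain from an amide-type nitrogen, gives an at least 3.7-fold higher number from compound 1 to compound 3 (0.56 log units; beyond the scatter). The value of compound 3 is a limit of the assay, not a number: the limit of >= 100000 nM in this assay, at which 1 of the 3 values shown sits.

This single exchange therefore moves the read-out beyond the scatter, which compound 1 and compound 2, differing in more than one place, could not show. On these data alone, how the same exchange acts on compound 2 stays open. So does the effect of a phenylthio group or a longer chain at this position.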